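Methoxy for Chloro on Two Different Rings

The source may report more compounds than this note shows. Statements on the series, on what has been measured and on what is new or still open speak of the compounds shown alone.

Compound 1 `CC1CCN(c2c(S(=O)(=O)c3cccc(Cl)c3)cnc3ccc(Cl)cc23)CC1` gives 92% in an assay on isolated protein for displacement of a labelled ligand from metabotropic glutamate receptor 5 (Homo sapiens), with a stated time of 60 min, tested at 1 uM; on this read-out higher numbers stand for more inhibition at the one concentration tested (going by the name of the read-out) and lower numbers for less inhibition.
Compound 2 `COc1ccc2ncc(S(=O)(=O)c3cccc(Cl)c3)c(N3CCC(C)CC3)c2c1` gives -3%.
Compound 3 `COc1ccc(S(=O)(=O)c2cnc3ccc(Cl)cc3c2N2CCC(C)CC2)cc1Cl` gives 46%.

Compound 2 differs from compound 1 by methoxy in place of chloro on an aromatic carbon, and the step is a number 95 percentage points lower from compound 1 to compound 2 (beyond the scatter). Compound 3 differs from compound 1 by methoxy in place of hydrogen on an aromatic carbon, with a number 46 percentage points lower from compound 1 to compound 3 (beyond the scatter). Compound 4 `COc1ccc(S(=O)(=O)c2cnc3ccc(Cl)cc3c2N2CCC(C)CC2)cc1OC` differs from compound 3 by methoxy in place of chloro on an aromatic carbon. This is the same kind of change as that from compound 1 to compound 2, not the same: there the place was part of a fused or bridged system of two rings, meta and para to a fused ring, whereas here it is ortho to a methoxy group and meta to a large group. The step expected for compound 4 in this assay is a number 24 percentage points lower from compound 3 to compound 4 (beyond the scatter), smaller than the earlier one because a number 95 percentage points lower from compound 1 to compound 2 (beyond the scatter) fell from a far higher start. Compound 4 is estimated at 22%, between 0% and 50%.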

Compound 4, a percentage reported as inhibition, at one concentration (the size of the read-out at that concentration, not a potency): 61%
Compound 4: middle estimate off by 39 percentage points, on the low side; the measured number lies above the stated range.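

Methoxy in place of chloro did not carry over from one core to the other in this assay: the same change on two cores in this assay, a number 95 percentage points lower (beyond the scatter) from compound 1 to compound 2 and a number 15 percentage points higher (beyond the scatter) from compound 3 to compound 4, 110 percentage points apart, beyond the scatter of two such steps

On the 3-chloro-4-methoxyphenyl group the change gives a number 15 percentage points higher from compound 3 to compound 4 (beyond the scatter), yet 3,4-dimethoxyphenyl in place of 3-chlorophenyl on the sulfonyl sulfur still leaves a number 31 percentage points lower from compound 1 to compound 4 (beyond the scatter). The two pairs show that the size and direction of this change depend on where it is made in this series, but they give no reason for the difference and no rule for any other place.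

From the compounds shown here alone, it remains open whether an ethoxy group or a fluoro group in the same place would follow methoxy. Going by these compounds, whether a third core would side with either pair also remains open.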